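The source may report more compounds than this note shows. Statements on the series, on what has been measured and on what is new or still open speak of the compounds shown alone.

Of the compounds shown here, two sharing one core have been measured in an assay on HEK293 cells for displacement of a labelled ligand from 5-hydroxytryptamine receptor 7 (Homo sapiens); a lower number here means a stronger inhibitor, a higher number a weaker inhibitor. Compound 1 `COc1ccccc1N1CCN(Cc2ccc(CN3C(=O)c4ccccc4S3(=O)=O)cc2)CC1` gives 97 nM there, and compound 2 `COc1ccccc1N1CCN(CCCCCN2C(=O)c3ccccc3S2(=O)=O)CC1` gives 125 nM in this assay, the larger number of the two, though the gap to compound 1 lies within the scatter. Compound 3 `O=C1c2ccccc2S(=O)(=O)N1CCCCCN1CCN(c2cccc(C(F)(F)F)c2)CC1` awaits measurement. Relative to compound 2 the change is 3-(trifluoromethyl)phenyl in place of 2-methoxyphenyl on an amine nitrogen in a ring. Among the compounds with values here, no measured pair covers this exchange. The step of a 2.0-fold higher number from compound 2 to compound 3 (0.30 log units; within the scatter) is expected to be small and toward a higher number, possibly within the scatter. Compound 3 is accordingly estimated at 250 nM, with a range from 80 nM to 800 nM.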

Compound 3, inhibition constant: 35 nM
The estimate for compound 3 lay 7.1-fold (0.85 log units) above the measured number, outside the stated range (below it).
By their numbers in this assay, from the lowest: compound 3; then compounds 1 and 2 (each within the scatter of the next).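

On the amine nitrogen in the ring, the aryl group is not interchangeable in this assay: 3-(trifluoromethyl)phenyl in place of 2-methoxyphenyl gives a 3.6-fold lower number from compound 2 to compound 3 (0.55 log units; beyond the scatter) and so moves the number beyond the scatter. The hydrogen-bond acceptor counted in 2-methoxyphenyl is therefore not needed for a low number in this series. Nothing at hand accounts for the step.

On these data alone, whether the step belongs to the trifluoromethyl group itself or to where it sits on the phenyl ring remains open. A chloro or nitrile group at this place, and the same exchange on the core of compound 1, would address this.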